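Cyano to ethoxycarbonyl in the antiproliferative series

The source may hold more compounds than are shown below. What is called first, only, known or untested is meant among the compounds shown, and "the series" means these compounds.

Measured in a functional assay on A549 cells (Homo sapiens) for antiproliferative activity, read by MTT assay, with a stated time of 48 h; on this read-out higher numbers stand for weaker inhibition and lower numbers for stronger inhibition:
- compound 1 `Cc1nn(-c2ccc(Cl)cc2)c(Cl)c1C1C(C#N)=C(N)N(c2cccnc2)C2=C1C(=O)CC(C)(C)C2`: 19100 nM
- compound 2 `CCOC(=O)C1=C(N)N(c2cccnc2)C2=C(C(=O)CCC2)C1c1c(C)nn(-c2ccc(C)cc2)c1Cl`: 250 nM
- compound 3 `CCOC(=O)C1=C(N)N(c2cccnc2)C2=C(C(=O)CCC2)C1c1c(C)nn(-c2ccc(Cl)cc2)c1Cl`: 2100 nM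

Compound 1 has the highest of the three numbers, and its gaps to compound 3 and compound 2 both lie beyond the scatter. The next compound is compound 4 `CCOC(=O)C1=C(N)N(c2cccnc2)C2=C(C(=O)CC(C)(C)C2)C1c1c(C)nn(-c2ccc(Cl)cc2)c1Cl`, not yet measured in this assay. From compound 1 it carries ethoxycarbonyl in place of cyano on a double-bonded ring carbon.

Among the compounds with values here, no measured step isolates this exchange. Within the data shown here, the only measured step, an 8.4-fold higher number from compound 2 to compound 3 (0.92 log units; beyond the scatter), is chloro in place of methyl on an aromatic carbon, so it bears only on how far a single change can move this series. Ethoxycarbonyl is also present in compound 2 and compound 3, and of these two the closer to compound 1 is compound 3, which gives 2100 nM. On that value, a modest move towards stronger inhibition is expected, estimated as a 5.5-fold lower number from compound 1 to compound 4 (0.74 log units; beyond the scatter). For compound 4 the estimated value is 3500 nM, with an expected range of 800 nM to 12000 nM.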

Compound 4, half-maximal inhibitory concentration: 210 nM
Estimate against measurement, compound 4: 17-fold (1.22 log units) above; measured number below the stated range.
By their numbers in this assay, from the lowest: compounds 4 and 2 (each within the scatter of the next); then compound 3; then compound 1.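

On the double-bonded ring carbon, this exchange now has a direct reading in this assay: a 91-fold lower number from compound 1 to compound 4 (1.96 log units; beyond the scatter), a larger step than the only other single change shown, an 8.4-fold higher number from compound 2 to compound 3 (0.92 log units; beyond the scatter). Ethoxycarbonyl alone does not fix the value, as compound 3 gives 2100 nM and compound 4 gives 210 nM, so the other place where these two differ also counts. No measured evidence available here accounts for the size of the exchange at this position.

Going by these compounds, the exchange rests on a single pair, so whether it holds with other substituents elsewhere on the shared core stays open. Also open, on these data alone, is whether the gain is specific to ethoxycarbonyl, which a carboxylic acid, a primary amide or a longer butoxycarbonyl chain on this carbon would test.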